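This account rests on a few compounds, and the source may have more. Where it says the series, first, only, none or still open, it means among the compounds named here.

In a functional assay on HL-60 cells (Homo sapiens) for antiproliferative activity, read by sulforhodamine B assay, with a stated time of 72 h (on this read-out lower numbers stand for stronger inhibition and higher numbers for weaker inhibition), compound 1 `COc1ccccc1NC(=S)N/N=C/c1ccc2ccccc2n1` gives 91700 nM, and compound 2 `S=C(N/N=C/c1ccc2ccccc2n1)Nc1cccc(Br)c1` gives 53800 nM. Compound 3 `Cc1ccc(NC(=O)N/N=C/c2ccc3ccccc3n2)cc1` shows > 100000 nM, which is a limit of the assay and not a number. Compound 2 therefore holds one of just two true numbers, and the other lies within the scatter of it. Compound 4 `S=C(N/N=C/c1ccc2ccccc2n1)Nc1ccc(Br)cc1` has the same atoms as compound 2, joined differently, with 4-bromophenyl in place of 3-bromophenyl on an amide-type nitrogen. For the measured compounds named here, only one measured step bears on this place: 3-bromophenyl in place of 2-methoxyphenyl gave a 1.7-fold lower number from compound 1 to compound 2 (0.23 log units; within the scatter), so no step beyond the scatter is expected in this assay, in either direction. The expected step is a 1.1-fold lower number from compound 2 to compound 4 (0.03 log units; within the scatter). Compound 4 is estimated at 50000 nM, with an expected range of 22000 nM to 100000 nM.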

Compound 4, half-maximal inhibitory concentration: 27500 nM
Beside the measured number, compound 4's estimate is 1.8-fold (0.26 log units) above it; the measured number falls inside the stated range.
By their numbers in this assay, from the lowest: compounds 4, 2 and 1 (each within the scatter of the next, the first and the last beyond it). At a limit, above all of these: compound 3.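

In this assay, 4-bromophenyl in place of 3-bromophenyl on the amide-type nitrogen gives a 2.0-fold lower number from compound 2 to compound 4 (0.29 log units; within the scatter) and so cannot be told apart from repeat variation. Yet 4-bromophenyl in place of 2-methoxyphenyl gives a 3.3-fold lower number from compound 1 to compound 4 (0.52 log units; beyond the scatter) and is the first step at this place to clear the scatter, though only modestly. Nothing measured here explains either step.

Still open, as far as these compounds go, is how an amine or a carboxylic acid on this phenyl ring would read out, and whether a longer chain could replace the ring.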